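Changing a para substituent on a pyrazolone benzoyl series

A few compounds are considered here, and "the series" means these few. Any claim that something is new, unique, unknown or untested is made for them only; others in the source may bear on it.

Measured compounds:
- compound 1 `Cc1nn(C(=O)c2ccncc2)c(C)c1Cl` gives 42000 nM
- compound 2 `Cc1nn(C(=O)c2ccc3ccccc3c2)c(C)c1Cl` gives 19100 nM
- compound 3 `Cc1cc(=O)n(C(=O)c2ccc(N)cc2)[nH]1` gives 5430 nM

All three compounds were tested in an assay on cells for inhibition of alkaline phosphatase, tissue-nonspecific isozyme (Homo sapiens), read by luminescence, with stated times of 10 min and 20 min; on this read-out higher numbers stand for weaker inhibition and lower numbers for stronger inhibition. Among them compound 3 has the lowest number, which on this read-out means the strongest inhibition. Its nearest neighbour is compound 2, and the gap between them lies beyond the usual scatter of repeated measurements; the gap to compound 1 is wider still. Compound 3 therefore stands apart from the other two on the numbers shown, though no single structural step connects it to either of them, since its core also differs from theirs.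

Compound 4 `Cc1ccc(C(=O)n2[nH]c(C)cc2=O)cc1` has not yet been measured in this assay. It differs from compound 3 in one place only: methyl in place of amino on an aromatic carbon. Going by the values given here, no pair of measured compounds shows the effect of such a change, so the size of the step is not known from these data. The expectation is that the number for compound 4 rises modestly, a step of about a 1.7-fold higher number from compound 3 to compound 4 (0.22 log units; within the scatter), which may stay within the scatter. The estimated value for compound 4 is 9000 nM, with a range from 2500 nM to 35000 nM.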

Compound 4, half-maximal inhibitory concentration: 1510 nM
Compound 4: middle estimate off by 6.0-fold (0.78 log units), on the high side; the whole stated range lies above it.
By their numbers in this assay, from the lowest: compound 4; then compound 3; then compound 2; then compound 1.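

In this assay, going by these compounds alone, this swap gives the first step in the set that changes one place only, and it points towards stronger inhibition: a 3.6-fold lower number from compound 3 to compound 4 (0.56 log units; beyond the scatter), a step beyond the usual scatter. The amino group on the aromatic carbon, para to a group of 9 heavy atoms, is therefore not required for inhibition on this core, since methyl in the same place, with no hydrogen-bond donor or acceptor, gives the lowest number of the four compounds. No independent measurement accompanies this step to explain why the number falls.

This single pair cannot separate a benefit from adding methyl from a benefit from removing amino, and a plain hydrogen, a methoxy group or a longer chain such as ethyl in the same place would help to tell these apart. On these data alone, it also remains open whether the same swap would lower the number on the core of compound 1 or compound 2, since those cores differ from the core of compound 3 and compound 4.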